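Shifting the Hydroxyl on an Inactive Anilide Series

The source may report more compounds than this note shows. Statements on the series, on what has been measured and on what is new or still open speak of the compounds shown alone.

Compound 1 `O=C(Nc1ccccc1O)C1c2ccccc2CCN1C(=O)c1ccc(Cl)cc1`: in a functional assay on NUGC-3 cells (Homo sapiens) for inhibition, read by sulforhodamine B assay, with a stated time of 48 h (a higher number here means a weaker inhibitor of growth, a lower number a stronger inhibitor of growth), compound 1 gives > 10000 nM, which is a limit of the assay.
Compound 2 `O=C(Nc1cccc(O)c1)C1NCCc2ccccc21`: in this assay compound 2 gives > 10000 nM, also a limit.
Compound 3 `O=C(Nc1ccccc1O)C1NCCc2ccccc21`: in this assay compound 3 gives > 10000 nM, again a limit.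

Compound 1 stands only at a limit, and so do the other two: the limit of > 10000 nM in this assay, at which 3 of the 3 values shown sit. Going by the values given here, the one measured step, a step that the two limits leave unreadable from compound 1 to compound 3, is therefore unreadable in size. Compound 2 and compound 3 show only limits, so their pairing tells nothing either.

Compound 4 `O=C(Nc1ccc(O)cc1)C1c2ccccc2CCN1C(=O)c1ccc(Cl)cc1` differs from compound 1 by 4-hydroxyphenyl in place of 2-hydroxyphenyl on an amide-type nitrogen. Among the compounds with values here, no measured step bears on this change, so no size or direction can be read for it in this assay. Compound 4 is expected to sit at about 20000 nM, in the range 8000 nM to 60000 nM, most likely reported only as a limit. The expected step that the limit leaves unreadable from compound 1 to compound 4 is thus one beyond nothing that the data can resolve.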

Compound 4, concentration for 50% growth inhibition: > 10000 nM
Compound 4: only a limit was reported; the forecaster's own chance of this, stated with the estimate: 85%; the middle value does not contradict the limit.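

In this assay compound 4 gives > 10000 nM, a limit. No step can be read from compound 1 to compound 4, as both stand at the same limit: the limit of > 10000 nM in this assay, at which 4 of the 4 values shown sit.

The compounds shown leave open whether any change to the shared core would give a measurable value in this assay.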